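Phenyl in place of oxan-4-yl on the amide carbonyl

The compounds below may be only part of what the source reports. "The series", "measured", "known", "first", "only" and "open" are said of these compounds alone.

Measured compounds:
compound 1 `Cc1cc(C(=O)NC(C)C)nn1Cc1cc(Cl)ccc1OCc1ccccc1`: 126 nM
compound 2 `Cc1cc(NC(=O)C2CCOCC2)nn1Cc1cc(Cl)ccc1OCc1ccccc1`: 63.1 nM

In an assay on CHO-K1 cells for displacement of a labelled ligand from prostaglandin E2 receptor EP1 subtype (Homo sapiens) (a lower number here means a stronger inhibitor, a higher number a weaker inhibitor), compound 2 gives the lowest of the two numbers, with compound 1 nearest; the step of a 2.0-fold lower number from compound 1 to compound 2 (0.30 log units; within the scatter) lies within the scatter. Compound 3 `Cc1cc(NC(=O)c2ccccc2)nn1Cc1cc(Cl)ccc1OCc1ccccc1` differs from compound 2 by phenyl in place of oxan-4-yl on a carbonyl carbon. Among the compounds with values here, no measured step concerns this kind of exchange; the one measured step, from compound 1 to compound 2, replaced a different group and stayed within the scatter, so it gives no direction. Compound 3 is therefore expected to show a 1.1-fold lower number from compound 2 to compound 3 (0.06 log units; within the scatter), no step beyond the scatter, with an estimated 55 nM and a range from 15 nM to 200 nM.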

Compound 3, half-maximal inhibitory concentration: 15.9 nM
Estimate against measurement, compound 3: 3.5-fold (0.54 log units) above; low and high end bracket the measured number.
By their numbers in this assay, from the lowest: compound 3; then compounds 2 and 1 (each within the scatter of the next).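

At this position, the group on the amide carbonyl does shift the result in this assay: phenyl in place of oxan-4-yl gives a 4.0-fold lower number from compound 2 to compound 3 (0.60 log units; beyond the scatter) and so moves the number beyond the scatter, which the step from compound 1 to compound 2 did not do. Benzamido in place of isopropylcarbamoyl gives a 7.9-fold lower number from compound 1 to compound 3 (0.90 log units; beyond the scatter) and is likewise beyond the scatter. Nothing available explains why phenyl gives the lower number.

The compounds shown leave open whether a pyridine ring would serve in place of phenyl. They also leave open how a methoxy group, an amine or a carboxylic acid on that phenyl would change the number.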